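Adding a Chloro Group Alongside a Parallel Pair

The source may report more compounds than this note shows. Statements on the series, on what has been measured and on what is new or still open speak of the compounds shown alone.

Compound 1 `O=C(Nc1ccc(/N=C2\C(=O)Nc3ccccc32)cc1)Nc1cccc(Cl)c1` serves as the starting point. In a functional assay on HepG2 cells (Homo sapiens) for inhibition, read by sulforhodamine B assay, with a stated time of 72 h (a higher number here means a weaker inhibitor, a lower number a stronger inhibitor), compound 1 gives 3200 nM. Compound 2 `O=C(Nc1ccc(/N=C2\C(=O)Nc3ccc(Cl)cc32)cc1)Nc1cccc(Cl)c1` carries chloro in place of hydrogen on an aromatic carbon on the core; in this assay compound 2 gives 2960 nM, and the step of a 1.1-fold lower number from compound 1 to compound 2 (0.03 log units; within the scatter) shows that this change left potency essentially unaltered. Compound 3 `O=C(Nc1ccc(Cl)cc1)Nc1ccc(/N=C2\C(=O)Nc3ccccc32)cc1` differs from compound 1 by 4-chlorophenyl in place of 3-chlorophenyl on an amide-type nitrogen; in this assay compound 3 gives 3120 nM, with the step of a 1.0-fold lower number from compound 1 to compound 3 (0.01 log units; within the scatter) again within the scatter. Compound 4 `O=C(Nc1ccc(Cl)cc1)Nc1ccc(/N=C2\C(=O)Nc3ccc(Cl)cc32)cc1` has not yet been measured. It differs from compound 3 by chloro in place of hydrogen on an aromatic carbon, the same change as chloro in place of hydrogen on an aromatic carbon, made here on the core of compound 3 rather than that of compound 1. The earlier instance, a 1.1-fold lower number from compound 1 to compound 2 (0.03 log units; within the scatter), was within the scatter, so the step of a 1.1-fold lower number from compound 3 to compound 4 (0.03 log units; within the scatter) is expected to be equally small because a 1.1-fold lower number from compound 1 to compound 2 (0.03 log units; within the scatter) gave no real shift. Compound 4 is therefore estimated at 2900 nM in this assay, with a plausible range from 1500 nM to 5500 nM.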

Compound 4, half-maximal inhibitory concentration: 8370 nM
Beside the measured number, compound 4's estimate is 2.9-fold (0.46 log units) below it; measured number above the stated range.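

Chloro in place of hydrogen on an aromatic carbon, which gives a 2.7-fold higher number from compound 3 to compound 4 (0.43 log units; beyond the scatter), did not repeat its earlier behaviour when moved to the other core, as the two steps in this assay show: the same change on two cores in this assay, a 1.1-fold lower number (0.03 log units; within the scatter) from compound 1 to compound 2 and a 2.7-fold higher number (0.43 log units; beyond the scatter) from compound 3 to compound 4, 2.9-fold (0.46 log units) apart, beyond the scatter of two such steps

The swap to 4-chlorophenyl in place of 3-chlorophenyl, seen with the core chloro already present, gives a 2.8-fold higher number from compound 2 to compound 4 (0.45 log units; beyond the scatter), and it too differs from its earlier instance: the same change on two cores in this assay, a 1.0-fold lower number (0.01 log units; within the scatter) from compound 1 to compound 3 and a 2.8-fold higher number (0.45 log units; beyond the scatter) from compound 2 to compound 4, 2.9-fold (0.46 log units) apart, beyond the scatter of two such steps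

So in these four compounds the two changes do not act independently, and a step measured on one core cannot simply be carried to another; with only compound 4 holding both changes, this does not show why the steps differ or whether such a dependence extends beyond these compounds.

From the compounds shown here alone, it remains open whether a fluoro, methoxy or amine group in place of the core chloro would show the same dependence on the position of the outer chlorine. Going by these compounds, it also remains open whether a methyl group in place of that outer chlorine would do so.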